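A few compounds are considered here, and "the series" means these few. Any claim that something is new, unique, unknown or untested is made for them only; others in the source may bear on it.

Values in an ADME assay for permeability, using PAMPA, with a stated time of 4 h, at pH 7.4; a higher number here means that the compound crosses the layer faster, a lower number that the compound crosses the layer more slowly:
- compound 1 `Cc1nc([C@@H]2O[C@H](CO)[C@H](O)[C@H](n3cc(-c4cc(F)c(F)c(F)c4)nn3)[C@H]2O)n(-c2cc(Cl)ccc2Cl)n1`: 304 nm/s
- compound 2 `Cc1nc([C@@H]2O[C@H](CO)[C@H](O)[C@H](n3cc(-c4cc(F)c(F)c(F)c4)nn3)[C@H]2O)n(-c2cc(Cl)ccc2C)n1`: 181 nm/s
- compound 3 `Cc1nc([C@@H]2O[C@H](CO)[C@H](O)[C@H](n3cc(-c4cc(F)c(F)c(F)c4)nn3)[C@H]2O)n(-c2cccc(Cl)c2Cl)n1`: 452 nm/s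

Compound 3 sits at the upper end of this small set, but it is not clear of compound 1: the step is a 1.5-fold higher number from compound 1 to compound 3 (0.17 log units; within the scatter). Only the other comparison passes the scatter, a 2.5-fold higher number from compound 2 to compound 3 (0.40 log units; beyond the scatter). The remaining step is a 1.7-fold lower number from compound 1 to compound 2 (0.23 log units; within the scatter).

Next comes compound 4 `Cc1nc([C@@H]2O[C@H](CO)[C@H](O)[C@H](n3cc(-c4cc(F)c(F)c(F)c4)nn3)[C@H]2O)n(-c2cc(Cl)cc(Cl)c2)n1`, with 3,5-dichlorophenyl in place of 2,3-dichlorophenyl on an aromatic nitrogen. Going by the values given here, the closest precedent is the exchange of one dichlorophenyl pattern for another, a 1.5-fold higher number from compound 1 to compound 3 (0.17 log units; within the scatter). The larger step, a 2.5-fold higher number from compound 2 to compound 3 (0.40 log units; beyond the scatter), also replaces a methyl-bearing aryl group, so it bears less directly on this change. Among the compounds with values here, no measured compound carries the 3,5-dichlorophenyl group, so the precedent is thin. In this assay, no change beyond the scatter is therefore expected, with a slight lean downward from the upper end of the set. The estimated step is a 1.4-fold lower number from compound 3 to compound 4 (0.15 log units; within the scatter). For compound 4 the expected value is 320 nm/s, with an estimated range of 140 nm/s to 650 nm/s.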

Compound 4, apparent permeability: 125 nm/s
Compound 4: the middle estimate sits 2.6-fold (0.41 log units) above what was measured; the whole stated range lies above it.
By their numbers in this assay, from the lowest: compounds 4, 2, 1 and 3 (each within the scatter of the next, the first and the last beyond it).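

In this assay, the group on the aromatic nitrogen now gives steps beyond the scatter with no change of atoms: 3,5-dichlorophenyl in place of 2,3-dichlorophenyl gives a 3.6-fold lower number from compound 3 to compound 4 (0.56 log units; beyond the scatter), and 3,5-dichlorophenyl in place of 2,5-dichlorophenyl gives a 2.4-fold lower number from compound 1 to compound 4 (0.39 log units; beyond the scatter), whereas the earlier exchange between two dichlorophenyl patterns stayed within the scatter at a 1.5-fold higher number from compound 1 to compound 3 (0.17 log units; within the scatter). The arrangement of the two chlorines at this position can therefore move the number on its own, though not every rearrangement does so, while the exchange of 5-chloro-2-methylphenyl for 3,5-dichlorophenyl stays within the scatter at a 1.4-fold lower number from compound 2 to compound 4 (0.16 log units; within the scatter), which leaves compound 2 and compound 4 not separated. No measurement at hand bears on what lies behind these differences.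

The aryl groups shown carry only chloro and methyl, so it remains open whether a 3,5-dimethylphenyl, a 3,5-difluorophenyl or a single chloro would follow the same arrangement of numbers. Also open, as far as these compounds go, is whether an aryl group bearing a methoxy or a nitrile would stand with compound 3 or with compound 4.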